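Replacing 3,4-dichlorophenyl with 2-bromo-5-fluorophenyl

A few compounds are considered here, and "the series" means these few. Any claim that something is new, unique, unknown or untested is made for them only; others in the source may bear on it.

Of the compounds shown here, three sharing one core have so far been measured in a functional assay on MCF7 cells (Homo sapiens) for inhibition, read by MTT assay (on this read-out higher numbers stand for weaker inhibition and lower numbers for stronger inhibition), as a way of comparing the group on the carbonyl carbon. Compound 1 (`COc1cc2ncnc(Nc3ccc(NC(=O)c4ccccc4C)cc3)c2cc1OC`) reads 21000 nM and compound 2 (`COc1cc2ncnc(Nc3ccc(NC(=O)c4cccc(C)c4)cc3)c2cc1OC`) reads 13000 nM while compound 3 (`COc1cc2ncnc(Nc3ccc(NC(=O)c4ccc(Cl)c(Cl)c4)cc3)c2cc1OC`) reads 25000 nM and so lies within the usual scatter of both others, which gives it no clear rank.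

Compound 4 (`COc1cc2ncnc(Nc3ccc(NC(=O)c4cc(F)ccc4Br)cc3)c2cc1OC`) has not yet been measured. It differs from compound 3 in one place (2-bromo-5-fluorophenyl in place of 3,4-dichlorophenyl on a carbonyl carbon), with 2-bromo-5-fluorophenyl in place of 3,4-dichlorophenyl on a carbonyl carbon.

Three measured swaps on that same carbonyl carbon bear on this change. They are a 1.6-fold lower number from compound 1 to compound 2 (0.21 log units; within the scatter) and a 1.2-fold higher number from compound 1 to compound 3 (0.08 log units; within the scatter) and, the largest of them, a 1.9-fold higher number from compound 2 to compound 3 (0.28 log units; within the scatter) and each lies within the scatter. Going by the values given here, no measured compound carries bromine or fluorine, so this evidence is only indirect.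

Resting on compound 3 at 25000 nM and on those small steps, no change beyond the scatter is expected in this assay and no firm direction can be predicted. The estimated step, drawn toward the middle of the three measured values, is a 1.3-fold lower number from compound 3 to compound 4 (0.12 log units; within the scatter) and remains a modest expectation. For compound 4 the estimated value is 19000 nM (expected range 8000 nM to 40000 nM).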

Compound 4, half-maximal inhibitory concentration: 26000 nM
The estimate for compound 4 lay 1.4-fold (0.14 log units) below the measured number; measured number inside the range.
By their numbers in this assay, from the lowest: compounds 2, 1, 3 and 4 (each within the scatter of the next).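

In this assay, going by these compounds alone, the swap to 2-bromo-5-fluorophenyl on the carbonyl carbon gives a 1.0-fold higher number from compound 3 to compound 4 (0.02 log units; within the scatter) and so brings the first group with bromine and fluorine into the series without a reading that can be told apart from that of 3,4-dichlorophenyl. The comparisons with the two methylphenyl compounds, a 2.0-fold higher number from compound 2 to compound 4 (0.30 log units; within the scatter) and a 1.2-fold higher number from compound 1 to compound 4 (0.09 log units; within the scatter) as well, also stay inside the scatter, although the first of these sits right at its edge. All four groups tried at this position therefore remain unresolved in this assay, and none can be ranked ahead of another, even with two different halogens now on the ring. Nothing available here offers an explanation for how closely these readings sit together.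

Every group shown on this carbonyl carbon is a substituted phenyl ring, so it stays open whether a basic amine such as a piperazine, a carboxylic acid or a longer alkyl chain in its place would shift the reading beyond the scatter. As far as these compounds go, whether changes to the methoxy groups of the shared core would do so is equally open.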